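From fluoro to trifluoromethoxy on a shared core

The compounds below may be only part of what the source reports. "The series", "measured", "known", "first", "only" and "open" are said of these compounds alone.

Compound 1 `Oc1cccc(-c2cc(-c3ccc(F)cc3)cc(-c3ccccc3O)n2)c1`: > 50000 nM (a limit)
Compound 2 `Oc1cccc(-c2cc(-c3ccc(F)cc3)cc(-c3cccc(O)c3)n2)c1`: 6310 nM
Compound 3 `Oc1ccc(-c2cc(-c3ccc(F)cc3)cc(-c3cccc(O)c3)n2)cc1`: 5020 nM

All three compounds were tested in a functional assay on HCT-15 cells (Homo sapiens) for inhibition; a lower number here means a stronger inhibitor, a higher number a weaker inhibitor. Compound 1 reached only a limit, > 50000 nM, and not a number. Exchanging its 2-hydroxyphenyl group gave an at least 7.9-fold lower number from compound 1 to compound 2 (0.89 log units; beyond the scatter) and an at least 9.9-fold lower number from compound 1 to compound 3 (0.99 log units; beyond the scatter). For the measured compounds named here, compound 3 gives 5020 nM, and its only numeric neighbour is no different: a 1.3-fold lower number from compound 2 to compound 3 (0.10 log units; within the scatter).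

Compound 4 `Oc1ccc(-c2cc(-c3ccc(OC(F)(F)F)cc3)cc(-c3cccc(O)c3)n2)cc1` carries trifluoromethoxy in place of fluoro on an aromatic carbon, (trifluoromethoxy in place of fluoro on an aromatic carbon). Going by the values given here, all the measured steps exchange hydroxyphenyl groups, and none touches this place, so they offer no direct size for the change. The starting point is therefore compound 3 at 5020 nM, and no shift beyond the scatter is expected in this assay. The estimated change is a 1.3-fold lower number from compound 3 to compound 4 (0.10 log units; within the scatter), with a wide margin in either direction. Compound 4 is expected at 4000 nM, with an estimated range from 1500 nM to 12000 nM.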

Compound 4, half-maximal inhibitory concentration: 1380 nM
The estimate for compound 4 lay 2.9-fold (0.46 log units) above the measured number, outside the stated range (below it).
By their numbers in this assay, from the lowest: compound 4; then compounds 3 and 2 (each within the scatter of the next). At a limit, above all of these: compound 1.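

For the compounds shown here, the earlier compounds all kept fluoro and varied only the hydroxyphenyl groups, so compound 4 is the first to show that this aromatic carbon matters in this assay: trifluoromethoxy in place of fluoro gave a 3.6-fold lower number from compound 3 to compound 4 (0.56 log units; beyond the scatter). The position therefore accepts a larger group than fluoro and responds to the exchange, though the step is modest. No measurement available here bears on why the number fell.

With a single step at this carbon, the compounds shown leave open how an amine, a carboxylic acid or a longer alkoxy chain would behave there. They also leave open whether the same exchange would give a step of similar size with the hydroxyphenyl groups of compound 2.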